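Benzoyl in place of phenylsulfonyl on the chain nitrogen

The source may report more compounds than this note shows. Statements on the series, on what has been measured and on what is new or still open speak of the compounds shown alone.

Compound 1 `Cc1ccc(S(=O)(=O)NCCNc2nccc(-c3c(-c4cccc(F)c4)nc4sccn34)n2)cc1` gives 15400 nM in a functional assay on A-375 cells (Homo sapiens) for cytotoxicity, read by MTT assay; on this read-out higher numbers stand for weaker inhibition and lower numbers for stronger inhibition. Compound 2 `O=S(=O)(NCCNc1nccc(-c2c(-c3cccc(F)c3)nc3sccn23)n1)c1ccccc1` gives 11000 nM in this assay, the lowest of the two numbers, with compound 1 as its nearest neighbour; the step of a 1.4-fold lower number from compound 1 to compound 2 (0.15 log units; within the scatter) lies within the scatter. Compound 3 `O=C(NCCNc1nccc(-c2c(-c3cccc(F)c3)nc3sccn23)n1)c1ccccc1` differs from compound 2 by benzoyl in place of phenylsulfonyl on an amine nitrogen, a benzoyl in place of phenylsulfonyl on an amine nitrogen. Within the data shown here, no measured step touches this part of the molecule; the only measured step, a 1.4-fold lower number from compound 1 to compound 2 (0.15 log units; within the scatter), concerns a methyl on an aromatic carbon and is within the scatter. One therefore expects no step beyond the scatter, no change at the digits printed from compound 2 to compound 3 (within the scatter). Compound 3 is estimated at 11000 nM, within 3500 nM to 35000 nM.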

Compound 3, half-maximal inhibitory concentration: 5060 nM
Beside the measured number, compound 3's estimate is 2.2-fold (0.34 log units) above it; low and high end bracket the measured number.
By their numbers in this assay, from the lowest: compound 3; then compounds 2 and 1 (each within the scatter of the next).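

In this assay, the group on the amine nitrogen moves the number beyond the scatter, which the methyl on the aromatic carbon did not do: benzoyl in place of phenylsulfonyl gives a 2.2-fold lower number from compound 2 to compound 3 (0.34 log units; beyond the scatter). Benzoyl in place of (4-methylphenyl)sulfonyl gives a 3.0-fold lower number from compound 1 to compound 3 (0.48 log units; beyond the scatter), so the change holds against both sulfonyl groups, though both steps are modest. No evidence on hand accounts for the change. Going by these compounds, whether an acetyl group on this nitrogen, or a longer chain carrying the benzamido group, would lower the number further stays open.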